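This account rests on a few compounds, and the source may have more. Where it says the series, first, only, none or still open, it means among the compounds named here.

Series notes. In a functional assay on HCT-116 cells (Homo sapiens) for inhibition, with a stated time of 72 h (on this read-out lower numbers stand for stronger inhibition and higher numbers for weaker inhibition), compound 1 (`Cc1cncc(S(=O)(=O)Nc2cccc3c(C#N)c[nH]c23)c1`) gives 190 nM and compound 2 (`N#Cc1c[nH]c2c(NS(=O)(=O)c3ccc(N)nc3)cccc12`) gives 640 nM on the same read-out. Compound 3 (`CNc1ccc(S(=O)(=O)Nc2cccc3c(Cl)c[nH]c23)cn1`) stands at 860 nM and so lies within the scatter of compound 2 and beyond the scatter from compound 1.

The next change leads to compound 4 (`O=S(=O)(Nc1cccc2c(Cl)c[nH]c12)c1ccc(NCCO)nc1`) and is hydroxymethyl in place of hydrogen on a saturated chain carbon bound to a nitrogen on an aromatic ring in the side chain, which reads methylamino to (2-hydroxyethyl)amino when cut one bond further out. Among the compounds with values here, no measured step alters this chain. Within the data shown here, the only single-place step in hand, a 3.4-fold higher number from compound 1 to compound 2 (0.53 log units; beyond the scatter) for 6-aminopyridin-3-yl in place of 5-methylpyridin-3-yl on a sulfonyl sulfur, is a different swap and gives only a rough scale. No shift beyond the scatter is therefore expected in this assay and neither direction is favoured. The estimated change is a 1.1-fold lower number from compound 3 to compound 4 (0.03 log units; within the scatter) and is expected to stay small. For compound 4 the expected value is 800 nM (estimated range 320 nM to 2000 nM).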

Compound 4, half-maximal inhibitory concentration: 650 nM
Beside the measured number, compound 4's estimate is 1.2-fold (0.09 log units) above it; measured number inside the range.
By their numbers in this assay, from the lowest: compound 1; then compounds 2, 4 and 3 (each within the scatter of the next).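

Adding hydroxymethyl on a saturated chain carbon bound to a nitrogen on an aromatic ring gives, in this assay, a 1.3-fold lower number from compound 3 to compound 4 (0.12 log units; within the scatter), so this is the first reading at this chain and it separates neither compound from the other. At this position, then, the extension from methylamino to (2-hydroxyethyl)amino, which enters with 2 heavy atoms, 1 hydrogen-bond donor and 1 hydrogen-bond acceptor, is accommodated without a shift that can be read on this cell read-out. No supporting data are available to explain this flat result.

On these data alone, the reading rests on one pair built on the core of compound 3, so it remains open whether the same change holds on the core of compound 1. Also open, as far as these compounds go, is whether a longer chain ending in an amine or a carboxylic acid would leave the number as flat.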